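The source may hold more compounds than are shown below. What is called first, only, known or untested is meant among the compounds shown, and "the series" means these compounds.

Compound 3 `N#Cc1ccc(-c2ccc(/C=N/N3C(=O)NC(=O)C3O)o2)cc1` belongs to a small set that shares its core with compound 1 `O=C1NC(=O)N(/N=C/c2ccc(-c3ccc(Cl)c(Cl)c3)o2)C1O` and compound 2 `O=C1NC(=O)N(/N=C/c2ccc(-c3ccc(Cl)cc3)o2)C1O`. For the measured compounds named here, in a functional assay on the whole organism for activation, with Mus musculus as the target, with a stated time of 60 min (on this read-out higher numbers stand for an effect only at larger amounts of compound and lower numbers for an effect already at smaller amounts), compound 1 gives 109 mg/kg, the only actual number so far. Compound 2 gives > 1000 mg/kg, which is a limit of the assay and not a number. Compound 3 gives > 1000 mg/kg, which is likewise a limit. Compound 3 therefore stands at the limit of > 1000 mg/kg in this assay, at which 2 of the 3 values shown sit.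

Compound 4 `CC(=O)Nc1ccc(-c2ccc(/C=N/N3C(=O)NC(=O)C3O)o2)cc1` differs from compound 3 by acetamido in place of cyano on an aromatic carbon, para to a large group (acetamido in place of cyano on an aromatic carbon). Going by the values given here, two measured steps bear on this position. Hydrogen in place of chloro gave an at least 9.1-fold higher number from compound 1 to compound 2 (0.96 log units; beyond the scatter), a change beyond the scatter, but it involves neither group in the present change. Cyano in place of chloro gave a step that the two limits leave unreadable from compound 2 to compound 3, and this is the closest precedent. Neither step measures acetamido. With a step that the two limits leave unreadable from compound 2 to compound 3 as the nearest evidence, no size can be carried over, so no step beyond the scatter is expected in this assay, and compound 4 is expected to stay near the limit. The expected change is a number no higher from compound 3 to compound 4 (the limit leaves the size open). For compound 4 the estimated value is 1000 mg/kg, with an expected range from 300 mg/kg to 2000 mg/kg.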

Compound 4, dose for half-maximal effect: > 1000 mg/kg
Compound 4 gave a limit, no number (the forecaster's own chance of this, stated with the estimate: 70%); the middle value sits exactly at the limit.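

In this assay compound 4 gives > 1000 mg/kg as a limit of the assay and not a number. Its steps from compound 2 and compound 3 therefore cannot be read, and it shares their limit: the limit of > 1000 mg/kg in this assay, at which 3 of the 4 values shown sit. The compounds shown leave open whether chloro, cyano and acetamido differ at all in this position.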